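The compounds below may be only part of what the source reports. "The series", "measured", "known", "first", "only" and "open" are said of these compounds alone.

Measured so far in a functional assay on DU-145 cells (Homo sapiens) for antiproliferative activity, read by MTT assay, with a stated time of 72 h; a lower number here means a stronger inhibitor, a higher number a weaker inhibitor:
compound 1 `COc1ccccc1/C=C/C(=O)c1ccc(OCC(=O)N[C@H]2CCOC2=O)cc1`: 10100 nM
compound 2 `O=C1OCC[C@@H]1NC(=S)SCCOc1ccccc1`: 63800 nM
compound 3 `O=C(CNc1ccccc1)N[C@H]1CCOC1=O`: > 64000 nM

Compound 1 holds the lowest of the two numbers; compound 2 sits above it, beyond the scatter. For compound 3 the assay reports only a limit, (the limit of > 64000 nM in this assay, at which 1 of the 3 values shown sits), not a number. For the measured compounds named here, no pair of measured compounds differs in a single place, so no measured step size is available for this series.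

Compound 4 `O=C(COc1ccc(C(=O)/C=C/c2ccccc2)cc1)N[C@H]1CCOC1=O` differs from compound 1 by hydrogen in place of methoxy on an aromatic carbon of the six-membered aromatic ring of carbon only, ortho to a large group. Nothing measured here covers a change of this kind. A step from compound 1 to compound 4 is expected to be small, within the scatter, if anything toward a higher number. The expected step is a 1.3-fold higher number from compound 1 to compound 4 (0.11 log units; within the scatter). Compound 4 is estimated at 13000 nM, with a range from 4500 nM to 40000 nM.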

Compound 4, half-maximal inhibitory concentration: 48300 nM
For compound 4 the middle estimate is 3.7-fold (0.57 log units) below the measured one; measured number above the stated range.
By their numbers in this assay, from the lowest: compound 1; then compounds 4 and 2 (each within the scatter of the next). At a limit, above all of these: compound 3.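

For the compounds shown here, replacing methoxy with hydrogen on this aromatic carbon, ortho to a large group, gives a 4.8-fold higher number from compound 1 to compound 4 (0.68 log units; beyond the scatter), the first single-place step in this assay. The 2-methoxyphenyl to phenyl change is therefore not neutral at this position, although this single modest step gives no general rule. Nothing shown here accounts for the size of the step.

On these data alone, whether ethoxy, hydroxyl or fluorine at this carbon would match the methoxy of compound 1 stays open. Also open, as far as these compounds go, is whether an amine here would move the number in either direction.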